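Methyl on a Cyclobutyl Carbamate: What to Expect

This account rests on a few compounds, and the source may have more. Where it says the series, first, only, none or still open, it means among the compounds named here.

Of the compounds shown here, three sharing one core have been tested in a functional assay on HEK293 cells for agonist activity at Glucose-dependent insulinotropic receptor (Homo sapiens), read by cAMP accumulation, with a stated time of 30 min; a higher number here means a larger maximal response, a lower number a smaller maximal response. Compound 1 `CC1(OC(=O)N2C[C@H]3COC[C@@H](C2)[C@@H]3Oc2ncnc(Nc3ccccc3F)c2F)CC1` gives 78%, and compound 3 `CC1(OC(=O)N2C[C@H]3COC[C@@H](C2)[C@@H]3Oc2ncnc(Nc3c(F)cccc3F)c2F)CC1` gives 78%. Compound 2 `N#Cc1ccc(Nc2ncnc(OC3C4COCC3CN(C(=O)OC3CCC3)C4)c2F)c(Cl)c1` gives 51%, the lowest of the three numbers, and its gap to both compound 1 and compound 3 lies beyond the scatter of this assay.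

Within the data shown here, the only single-point step measured so far, no change at the digits printed from compound 1 to compound 3 (within the scatter), concerns a fluoro in place of hydrogen on an aromatic carbon, far from the carbamate end of the molecule; it offers no direct guidance for a change on a saturated ring.

Compound 4 `CC1(OC(=O)N2CC3COCC(C2)C3Oc2ncnc(Nc3ccc(C#N)cc3Cl)c2F)CCC1` differs from compound 2 by one change: methyl in place of hydrogen on a saturated ring carbon. Among the measured compounds shown here, no measured pair isolates this change, so there is no basis for expecting a step beyond the scatter in either direction.

Compound 4 is therefore expected to show 55%, within a range of 35% to 75%, which as an expected step reads a number 4 percentage points higher from compound 2 to compound 4 (within the scatter).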

Compound 4, largest response reached (reported as percent of maximum), in percent of the reference or control that the assay uses: 59%
Estimate against measurement, compound 4: 4 percentage points below, and the stated range covers the measured number.
By their numbers in this assay, from the lowest: compounds 2 and 4 (each within the scatter of the next); then compounds 1 and 3 (each within the scatter of the next).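

In this assay, among these compounds, the change from cyclobutyl to 1-methylcyclobutyl gives a number 8 percentage points higher from compound 2 to compound 4 (within the scatter), so one added methyl on this saturated ring carbon leaves no step that can be told apart from the scatter. Among the compounds shown here, the earlier compounds offered only a fluoro step on an aromatic carbon, so this pair is the first direct reading of a change on a four-membered non-aromatic ring of carbon only. Nothing available here explains the result in terms of how the methyl acts.

The compounds shown leave open what an ethyl group, a hydroxyl or an amine on this same carbon would do to the maximal response. A single pair also cannot say whether a methyl here would read the same with a different aromatic group on the shared core.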